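A few compounds are considered here, and "the series" means these few. Any claim that something is new, unique, unknown or untested is made for them only; others in the source may bear on it.

The measured compounds in a functional assay for inhibition, with Homo sapiens as the target; a lower number here means a stronger inhibitor, a higher number a weaker inhibitor:
Compound 1 `C=CCSc1nncc2cnc(CCC)n12` sits at the assay limit, > 48000 nM.
Compound 2 `C=CCSc1nncc2cnc(-c3ccccc3)n12` also sits at the assay limit, > 48000 nM.
Compound 3 `C=CCSc1nncc2cnc(COC)n12` gives 79000 nM.

Compound 2 thus has only a limit and no number; it shares that limit with one other compound (the limit of > 48000 nM in this assay, at which 2 of the 3 values shown sit). The steps around it are unreadable: a step that the two limits leave unreadable from compound 1 to compound 2 and a step that the limit leaves unreadable from compound 2 to compound 3. Compound 4 `C=CCSc1nncc2c(C)nc(-c3ccccc3)n12` differs from compound 2 by methyl in place of hydrogen on an aromatic carbon. Going by the values given here, no measured step touches that position, and the two steps bearing on compound 2 give no readable size, so no direction can be taken from them. Compound 4 is expected to stay near the limit, the step that the limit leaves unreadable from compound 2 to compound 4 being an estimate of no change beyond the scatter. The estimate for compound 4 is 80000 nM, ranging from 30000 nM to 200000 nM.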

Compound 4, half-maximal inhibitory concentration: > 48000 nM
Compound 4 was reported as a limit; the forecaster's own chance of this, stated with the estimate: 70%; the middle value is on the limit's open side.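

In this assay compound 4 gives > 48000 nM, which is a limit and not a number. Going by these compounds alone, compound 2 also has only a limit, so no step between compound 2 and compound 4 can be read. The compounds shown leave open whether methyl in place of hydrogen on this aromatic carbon changes inhibition at all.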